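A few compounds are considered here, and "the series" means these few. Any claim that something is new, unique, unknown or untested is made for them only; others in the source may bear on it.

Measured compounds:
- compound 1 `CC(C)CCn1nc(-c2cccs2)c(O)c(C2=NS(=O)(=O)c3cc(S(=O)(=O)N(C)C)ccc3N2)c1=O`, in an in vitro ADME assay on microsomes from liver (Homo sapiens) for metabolic stability, tested at 5 uM (a lower number here means that the compound disappears faster, a higher number that the compound lasts longer), compound 1 gives 0.183 h
- compound 2 `CC(C)CCn1nc(CCC(F)(F)F)c(O)c(C2=NS(=O)(=O)c3cc(NS(C)(=O)=O)ccc3N2)c1=O`, in this assay compound 2 gives 0.517 h
- compound 3 `CC(C)Cn1nc(-c2cccs2)c(O)c(C2=NS(=O)(=O)c3cc(NS(C)(=O)=O)ccc3N2)c1=O`, for which this assay reports only a limit, > 1 h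

Compound 3 therefore stands at the limit of > 1 h in this assay, at which 1 of the 3 values shown sits, and not at a number; its half-life is not resolved beyond that limit. For the measured compounds named here, compounds 1 and 2 each differ from compound 3 in more than one place, so no single step connects them and their values are read only as given.

Compound 4 `CS(=O)(=O)Nc1ccc2c(c1)S(=O)(=O)N=C(c1c(O)c(-c3cccs3)nn(Cc3ccc(F)cc3)c1=O)N2` is not yet measured. From compound 3 it differs in one place: 4-fluorophenyl in place of isopropyl on a saturated chain carbon bound to an aromatic nitrogen.

Going by the values given here, no measured step covers this change, and nothing among the measured compounds speaks to what it does to half-life. The expectation is therefore set close to compound 3 with a wide range, allowing a modest drop as well as the chance that the assay again reports only a limit. For compound 4 the half-life in this assay is estimated at 0.8 h, between 0.3 h and 2 h, which means an expected step of an at least 1.2-fold lower number from compound 3 to compound 4 (0.09 log units; that floor lies within the scatter).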

Compound 4, half-life: > 1 h
Compound 4 was reported as a limit; the forecaster's own chance of this, stated with the estimate: 40%; middle value at least 1.2-fold (0.09 log units) away from the limit.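

For the compounds shown here, compound 3 and compound 4 each give only a limit in this assay, so no step between them can be read: the limit of > 1 h in this assay, at which 2 of the 4 values shown sit. The compounds shown leave open how long either half-life actually is, and whether 4-fluorophenyl in place of isopropyl changes it at all.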